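The source may report more compounds than this note shows. Statements on the series, on what has been measured and on what is new or still open speak of the compounds shown alone.

Series notes. For the measured compounds named here, in a functional assay on Jurkat cells for inhibition of nuclear factor NF-kappa-B complex (Homo sapiens) (on this read-out higher numbers stand for weaker inhibition and lower numbers for stronger inhibition), compound 2 `CCOC(=O)c1cnc(-c2ccc(F)cc2)nc1NN1C(=O)C=C(C)C1=O` gives 700 nM, the lowest of the two numbers so far; the nearest is compound 1 `CCOC(=O)c1cnc(-c2cnc3ccccc3c2)nc1NN1C(=O)C=C(C)C1=O`, which in this assay gives 6000 nM. Going by the values given here, the one measured step, an 8.6-fold lower number from compound 1 to compound 2 (0.93 log units; beyond the scatter), alters the same position that is varied next, and shows that the group on that carbon shifts the number by a meaningful margin. Compound 3 `CCOC(=O)c1cnc(Oc2ccccc2)nc1NN1C(=O)C=C(C)C1=O` carries the change (phenoxy in place of 4-fluorophenyl on an aromatic carbon); the carbon bearing the new group sits between two ring nitrogen atoms and para to the ethoxycarbonyl group. Among the compounds with values here, no measured pair exchanges an aryl group for an aryloxy group, so the size of this step is uncertain, and the step from compound 1 to compound 2 only indicates that the position is sensitive. For compound 3 a somewhat weaker inhibition is expected, the step being a 2.1-fold higher number from compound 2 to compound 3 (0.33 log units; beyond the scatter). Compound 3 is therefore estimated at 1500 nM in this assay, within 300 nM to 8000 nM.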

Compound 3, half-maximal inhibitory concentration: 15000 nM
Estimate against measurement, compound 3: 10-fold (1.00 log units) below; measured number above the stated range.
By their numbers in this assay, from the lowest: compound 2; then compound 1; then compound 3.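

In this assay the step of a 21-fold higher number from compound 2 to compound 3 (1.33 log units; beyond the scatter) is large, so this carbon between two ring nitrogen atoms does not tolerate phenoxy in place of 4-fluorophenyl, even though each group carries one six-membered aromatic ring of carbon only. The step of a 2.5-fold higher number from compound 1 to compound 3 (0.40 log units; beyond the scatter) places phenoxy behind quinolin-3-yl as well, giving the order 4-fluorophenyl, quinolin-3-yl, phenoxy from lowest to highest number, so an aromatic ring on this carbon does not alone set the number. Nothing available bears on why this change costs so much.

The step swaps the attached atom and removes the fluorine together, so the two changes cannot be separated. A 4-fluorophenoxy group would separate them, and an anilino group would show whether the loss extends to other linking atoms.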